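The source may hold more compounds than are shown below. What is called first, only, known or untested is meant among the compounds shown, and "the series" means these compounds.

- Compound 1 `CN1CC[C@H](c2c(O)cc(O)c3c(=O)cc(/C=C/c4ccccc4)oc23)[C@H](O)C1` gives 8%
- Compound 2 `CN1CC[C@H](c2c(O)cc(O)c3c(=O)cc(/C=C/c4ccc(Cl)cc4)oc23)[C@H](O)C1` gives 10%

Going by the values given here, in a functional assay on MCF7 cells (Homo sapiens) for inhibition, read by MTT assay, with a stated time of 48 h, tested at 10 uM (on this read-out lower numbers stand for less inhibition of growth and higher numbers for more inhibition of growth at the one concentration tested), compound 2, at 10%, stands within the scatter of compound 1, the only other compound measured so far. Compound 3 `CN1CC[C@H](c2c(O)cc(O)c3c(=O)cc(/C=C/c4cccc(Cl)c4)oc23)[C@H](O)C1` differs from compound 2 in one place: 3-chlorophenyl in place of 4-chlorophenyl on a double-bonded chain carbon bound to a double-bonded chain carbon. It carries 3-chlorophenyl in place of 4-chlorophenyl on a double-bonded chain carbon bound to a double-bonded chain carbon, so the two have the same atoms, joined differently. Among the compounds with values here, one measured step bears on this, and only indirectly: chloro in place of hydrogen on an aromatic carbon gave a number 2 percentage points higher from compound 1 to compound 2 (within the scatter). Within the data shown here, no measured pair shows what moving the chloro does. A step beyond the scatter is therefore not expected in this assay, and no direction is favoured. The estimated step is no change at the digits printed from compound 2 to compound 3 (within the scatter). Compound 3 is expected at 10%, within an estimated range of 2% to 20%.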

Compound 3, percent growth inhibition at one concentration: 82%
Beside the measured number, compound 3's estimate is 72 percentage points below it; the measured number lies above the stated range.
By their numbers in this assay, from the lowest: compounds 1 and 2 (each within the scatter of the next); then compound 3.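

In this assay the exchange of 4-chlorophenyl for 3-chlorophenyl, with the same atoms joined differently, gives a number 72 percentage points higher from compound 2 to compound 3 (beyond the scatter), so where the chloro sits decides the result in a way the earlier pair could not show. Chloro in place of hydrogen on an aromatic carbon therefore has no single outcome in this series: as 3-chlorophenyl it gives a number 74 percentage points higher from compound 1 to compound 3 (beyond the scatter), whereas as 4-chlorophenyl it gave a number 2 percentage points higher from compound 1 to compound 2 (within the scatter). Nothing available here explains why the two isomers differ so widely.

The compounds shown leave open whether the chloro itself matters, or whether 3-bromophenyl or 3-methoxyphenyl in the same place would give a similar number. From the compounds shown here alone, since the read-out covers a single concentration, how compound 3 behaves at other concentrations also remains open.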